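The compounds below may be only part of what the source reports. "The series", "measured", "known", "first", "only" and "open" are said of these compounds alone.

- Compound 1 `O=C1NC(=O)c2ccc(I)cc2/C1=C/Nc1ccc(CN2CCCCC2)cc1`: 2700 nM
- Compound 2 `CN1CC2CC1CN2c1ccc(N/C=C2\C(=O)NC(=O)c3ccc(I)cc32)cc1`: 1900 nM

In a functional assay on HCT-116 cells (Homo sapiens) for antiproliferative activity, read by sulforhodamine B assay (on this read-out higher numbers stand for weaker inhibition and lower numbers for stronger inhibition), compound 1 gives 2700 nM and compound 2 gives 1900 nM, two numbers within the scatter of each other. Compound 3 `C[C@@H]1CN(c2ccc(N/C=C3\C(=O)NC(=O)c4ccc(I)cc43)cc2)[C@@H](C)CN1C` differs from compound 2 by a group of 9 heavy atoms (7 carbon, 2 nitrogen; one six-membered non-aromatic ring with 2 hetero atoms) in place of a group of 8 heavy atoms (6 carbon, 2 nitrogen; 2 five-membered non-aromatic rings with 1 hetero atom each), on an aromatic carbon, which places a 2,4,5-trimethylpiperazin-1-yl group on an aromatic carbon. Within the data shown here, only one measured step bears on this change: a 1.4-fold lower number from compound 1 to compound 2 (0.15 log units; within the scatter), which also exchanged the group on an aromatic carbon. The expected change is therefore none beyond the scatter, with an estimated 1.2-fold higher number from compound 2 to compound 3 (0.06 log units; within the scatter). The estimate for compound 3 is 2200 nM, with an expected range of 900 nM to 5000 nM.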

Compound 3, half-maximal inhibitory concentration in the HCT-116 assay: 5000 nM
Estimate against measurement, compound 3: 2.3-fold (0.36 log units) below; measured number inside the range.
By their numbers in the HCT-116 assay, from the lowest: compounds 2, 1 and 3 (each within the scatter of the next, the first and the last beyond it).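

At this place, para to a large group, the earlier exchange had stayed within the scatter, but in the HCT-116 assay the 2,4,5-trimethylpiperazin-1-yl group brings a step beyond it: a 2.6-fold higher number from compound 2 to compound 3 (0.42 log units; beyond the scatter). Set against the (piperidin-1-yl)methyl group, the same entering group stays within the scatter in the HCT-116 assay: a 1.9-fold higher number from compound 1 to compound 3 (0.27 log units; within the scatter). In a physicochemical assay for solubility, at pH 7.4 (a lower number here means a less soluble compound, a higher number a more soluble compound), compound 2 gives 18 ug/mL and compound 3 gives 4 ug/mL. The exchange for the bridged group also lowers the number in the physicochemical assay: the measured solubility of compound 2, 18 ug/mL, and of compound 3, 4 ug/mL, a 4.5-fold lower number (0.65 log units; beyond the scatter).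

The compounds shown do not separate the ring from its methyl groups or their defined stereocentres. Going by these compounds, how an unsubstituted piperazine or a morpholine would stand here remains open.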